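Replacing 4-methylpiperidin-1-yl with diethylamino: a small expected step

This account rests on a few compounds, and the source may have more. Where it says the series, first, only, none or still open, it means among the compounds named here.

Of the compounds shown here, three have been measured so far in a functional assay on NCI-H460 cells (Homo sapiens) for cytotoxicity, read by MTT assay, with a stated time of 72 h; on this read-out lower numbers stand for stronger inhibition and higher numbers for weaker inhibition. Compound 3 `CC1CCN(Cc2ccc3nc(NC(=O)N/N=C4\C(=O)Nc5ccc(F)cc54)sc3c2)CC1` gives 1430 nM, and compound 1 `CN(C)Cc1ccc2nc(NC(=O)N/N=C3\C(=O)Nc4ccc(F)cc43)sc2c1` gives 1550 nM, so these two sit level within the usual scatter of repeated measurements. Compound 2 `CC1CCN(Cc2ccc3nc(NC(=O)N/N=C/c4c[nH]c5ccccc45)sc3c2)CC1` gives 4130 nM, beyond that scatter from compound 3 and on the weaker side. Compound 3 therefore belongs to the better pair of the three, without standing apart from compound 1.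

The next compound, compound 4 `CCN(CC)Cc1ccc2nc(NC(=O)N/N=C3\C(=O)Nc4ccc(F)cc43)sc2c1`, changes a single group of compound 3: diethylamino in place of 4-methylpiperidin-1-yl on a saturated chain carbon bound to an aromatic carbon. In words, diethylamino stands in place of 4-methylpiperidin-1-yl on a saturated chain carbon bound to an aromatic carbon.

For the measured compounds named here, one measured step bears on this change. It is a 1.1-fold lower number from compound 1 to compound 3 (0.03 log units; within the scatter), where 4-methylpiperidin-1-yl took the place of dimethylamino at the same carbon. Diethylamino, like dimethylamino, carries no ring, so the new change runs in the reverse direction to that exchange, though with a larger group. A single step is thin evidence, but it showed no real movement. In this assay, the expected result is therefore no change beyond the scatter, with an estimated 1.0-fold higher number from compound 3 to compound 4 (0.02 log units; within the scatter). For compound 4 the estimate is 1500 nM, with an expected range from 800 nM to 2800 nM.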

Compound 4, half-maximal inhibitory concentration: 1060 nM
For compound 4 the middle estimate is 1.4-fold (0.15 log units) above the measured one; the range from low to high includes it.
By their numbers in this assay, from the lowest: compounds 4, 3 and 1 (each within the scatter of the next); then compound 2.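

For the compounds shown here, the step of a 1.3-fold lower number from compound 3 to compound 4 (0.13 log units; within the scatter) and the step of a 1.5-fold lower number from compound 1 to compound 4 (0.17 log units; within the scatter) in this assay both lie within the scatter, as did the one earlier step at this carbon. Compounds 1, 3 and 4 therefore now form a set of three amines on the same saturated chain carbon, and the two open-chain groups, dimethylamino and diethylamino, and the ring group, 4-methylpiperidin-1-yl, cannot be told apart by this read-out; no compound among these three goes against that reading, though it covers only these groups on this one core. No measurement is available that could explain this lack of separation.

All three groups are tertiary amines with only carbon substituents on the nitrogen, so the compounds shown leave open whether a morpholin-4-yl ring, a piperazin-1-yl ring or a primary amine at this carbon would also fall within the scatter. On these data alone, it also stays open whether the nitrogen is needed at all, which a carboxylic acid or a plain alkyl chain in its place would test.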